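A few compounds are considered here, and "the series" means these few. Any claim that something is new, unique, unknown or untested is made for them only; others in the source may bear on it.

Compound 1 `N#CC1CN1C(=O)Nc1ccc(F)cc1` was tested in a functional assay on WiDr cells (Homo sapiens) for inhibition (on this read-out lower numbers stand for stronger inhibition and higher numbers for weaker inhibition), where compound 1 gives 9000 nM, the only outright number among the results shown. Compound 2 `CC(C)(C)NC(=O)N1CC1C#N` was tested as well. In this assay compound 2 reaches only a limit of the assay, > 300000 nM. So compound 1 stands alone with a number, the other result sitting at the limit of > 300000 nM in this assay, at which 1 of the 2 values shown sits. Compound 3 `N#CC1CN1C(=O)Nc1ccc(S(N)(=O)=O)cc1` arises from compound 1 by sulfamoyl in place of fluoro on an aromatic carbon. Among the measured compounds shown here, no measured pair shows such a change, so the step expected in this assay is a 1.7-fold higher number from compound 1 to compound 3 (0.22 log units; within the scatter), with no firm direction beyond the scatter. Compound 3 is therefore estimated at 15000 nM, within 3000 nM to 80000 nM.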

Compound 3, half-maximal inhibitory concentration: > 38000 nM
Compound 3 ended at the assay's limit; the forecaster's own chance of this, stated with the estimate: 15%; at least 2.5-fold (0.40 log units) between middle value and limit.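

Among the compounds shown here, this is the first measured change at this position of the aromatic ring: sulfamoyl in place of fluoro gives an at least 4.2-fold higher number from compound 1 to compound 3 (0.62 log units; beyond the scatter) in this assay. The position is therefore not indifferent to what sits there, as the step lies beyond the usual scatter. Going by these compounds, the true size of the step stays unknown, since compound 3 gives only a limit of the assay, > 38000 nM.

The compounds shown leave open whether an amine, a carboxylic acid or a chloro group at this place would keep the activity of compound 1. They also leave open whether any group here could improve on fluoro.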